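A Chlorophenyl Swap Carried Over from a Neighbouring Pair

This account rests on a few compounds, and the source may have more. Where it says the series, first, only, none or still open, it means among the compounds named here.

Three compounds have been measured in a functional assay on NCI-H460 cells (Homo sapiens) for inhibition, read by MTT assay, with a stated time of 72 h; a higher number here means a weaker inhibitor, a lower number a stronger inhibitor:

compound 1, `COc1cc(NC(C)CCCNC(=O)NNC(=O)Nc2ccc(Cl)cc2)c2ncccc2c1`, 63000 nM
compound 2, `COc1cc(NC(C)CCCNC(=O)Nc2cccc(C(F)(F)F)c2)c2ncccc2c1`, 21000 nM
compound 3, `COc1cc(NC(C)CCCNC(=O)NNC(=O)Nc2cccc(C(F)(F)F)c2)c2ncccc2c1`, 20000 nM

The unmeasured member of the set is compound 4, `COc1cc(NC(C)CCCNC(=O)Nc2ccc(Cl)cc2)c2ncccc2c1`. Compound 4 differs from compound 2 by one change: 4-chlorophenyl in place of 3-(trifluoromethyl)phenyl on an amide-type nitrogen. The same change separates compound 3 from compound 1: 4-chlorophenyl in place of 3-(trifluoromethyl)phenyl on an amide-type nitrogen. In both cases the place is an amide-type nitrogen whose other neighbour is a carbonyl carbon, so the two are the same change, made on two different cores. How the core of compound 2 differs from the core of compound 3 is not broken down here; compound 2 and compound 3 give numbers within the usual scatter of each other, so nothing can be said about an order between them. Going by the values given here, the one measured instance of the change reads a 3.2-fold higher number from compound 3 to compound 1 (0.50 log units; beyond the scatter). The remaining measured step, a 3.0-fold lower number from compound 1 to compound 2 (0.48 log units; beyond the scatter), covers a larger change in the chain and is not the same kind of change.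

Among the compounds with values here, compound 4 is expected to give a higher number than compound 2 because a 3.2-fold higher number from compound 3 to compound 1 (0.50 log units; beyond the scatter) is the only measured instance of this change and lies beyond the scatter. The expected step is a 2.4-fold higher number from compound 2 to compound 4 (0.38 log units; beyond the scatter), held somewhat short of the measured one since the core differs. For compound 4 in this assay the estimate is 50000 nM, with a range from 20000 nM to 120000 nM.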

Compound 4, half-maximal inhibitory concentration: 34000 nM
Compound 4: middle estimate off by 1.5-fold (0.17 log units), on the high side, within the range that was stated.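

In this assay the change from 3-(trifluoromethyl)phenyl to 4-chlorophenyl, now read on a second core, gives a 1.6-fold higher number from compound 2 to compound 4 (0.21 log units; within the scatter), and the other new step, which replaces ((4-chlorophenyl)carbamoyl)amino with 4-chlorophenyl on the amide-type nitrogen, gives a 1.9-fold lower number from compound 1 to compound 4 (0.27 log units; within the scatter). Set side by side, the two instances of the change cannot be told apart: the same change on two cores in this assay, a 3.2-fold higher number (0.50 log units; beyond the scatter) from compound 3 to compound 1 and a 1.6-fold higher number (0.21 log units; within the scatter) from compound 2 to compound 4, 1.9-fold (0.29 log units) apart, within the scatter of two such steps

Going by these compounds alone, the result is therefore compatible with the change carrying over between these two cores, but it does not establish a transferable step, as only one of the two readings lies beyond the scatter and two cores are too few to support a rule for the series.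

The two aryl groups shown differ in both their substituent and its place on the ring, so it remains open whether 3-chlorophenyl or 4-(trifluoromethyl)phenyl would separate these two features. Going by these compounds, it is also open how the change would read with a plain phenyl as the reference group, or on a core with a shorter chain or a simple amine in place of the urea.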